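Cytotoxicity in the pyrazole amide series: difluorophenyl variant

This account rests on a few compounds, and the source may have more. Where it says the series, first, only, none or still open, it means among the compounds named here.

Compound 1 `CO[C@H]1CC[C@H](NC(=O)c2n[nH]cc2NC(=O)c2cc3ccccc3o2)CC1` and compound 2 `CO[C@H]1CC[C@H](NC(=O)c2n[nH]cc2NC(=O)c2ccccc2)CC1` share the same core and differ only in the group on the carbonyl carbon. In an ADME assay on MRC5 cells (Homo sapiens) for inhibition, with a stated time of 72 h (a higher number here means that more compound is needed for the effect, a lower number that less compound is needed), compound 1 gives 800 nM and compound 2 gives 800 nM. The step of no change at the digits printed from compound 1 to compound 2 (within the scatter) shows that phenyl in place of 1-benzofuran-2-yl on a carbonyl carbon left the read-out unchanged, so compound 2 stands level with compound 1 and there is no gradient in the series to follow. Compound 3 `CO[C@H]1CC[C@H](NC(=O)c2n[nH]cc2NC(=O)c2cc(F)cc(F)c2)CC1` carries 3,5-difluorophenyl in place of phenyl on a carbonyl carbon. Among the compounds with values here, no measured step bears directly on fluorine on this ring; the single step available, from the benzofuran to phenyl, stayed within the scatter, and the new group keeps one six-membered aromatic ring of carbon only. No step beyond the scatter is therefore expected, no change at the digits printed from compound 2 to compound 3 (within the scatter). For compound 3 in this assay the estimated value is 800 nM, with a range from 400 nM to 1600 nM.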

Compound 3, half-maximal effective concentration: 600 nM
Compound 3: the middle estimate sits 1.3-fold (0.12 log units) above what was measured; the measured number falls inside the stated range.
By their numbers in this assay, from the lowest: compounds 3, 1 and 2 (each within the scatter of the next).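

In this assay there is a 1.3-fold lower number from compound 2 to compound 3 (0.12 log units; within the scatter) with 3,5-difluorophenyl in place of phenyl on a carbonyl carbon and a 1.3-fold lower number from compound 1 to compound 3 (0.12 log units; within the scatter) with 3,5-difluorophenyl in place of 1-benzofuran-2-yl. This extends the earlier flat step to a ring carrying two fluorine atoms: phenyl, 1-benzofuran-2-yl and 3,5-difluorophenyl all lie within the scatter of one another at this position. No measured data explain this flat read-out.

Still open, from the compounds shown here alone, is whether any group on this carbonyl carbon can move the number beyond the scatter, for example a phenyl ring carrying a carboxylic acid or a primary amine, or a saturated cyclohexyl ring. Also open, going by these compounds, is whether the same flat read-out would hold once the other amide substituent of the shared core is changed.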